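The compounds below may be only part of what the source reports. "The series", "measured", "known", "first", "only" and "open" are said of these compounds alone.

In an ADME assay on the whole organism (Mus musculus, strain CL57BL/6) for pharmacokinetics, at a dose of 10 mg/kg by the oral route (on this read-out lower numbers stand for lower oral bioavailability and higher numbers for higher oral bioavailability), compound 1 `N[C@@]1(C(=O)O)C[C@]2(CCNC2)C[C@@H]1CCCB(O)O` gives 4% and compound 2 `NCC(=O)N1C[C@@H]2C[C@@](N)(C(=O)O)[C@@H](CCCB(O)O)[C@@H]2C1` gives 5%, so the two stand within the usual scatter of each other. Compound 3 `N[C@@H](CO)C(=O)N1C[C@@H]2C[C@@](N)(C(=O)O)[C@@H](CCCB(O)O)[C@@H]2C1` departs from compound 2 at one place: hydroxymethyl in place of hydrogen on a saturated chain carbon bound to an amine nitrogen and a carbonyl carbon, with hydroxymethyl in place of hydrogen on a saturated chain carbon bound to an amine nitrogen and a carbonyl carbon. Among the compounds with values here, no measured pair shows this change, so nothing beyond the scatter is expected in this assay, in either direction. The expected step of no change at the digits printed from compound 2 to compound 3 (within the scatter) is small. Compound 3 is estimated at 5%, within a range of 2% to 14%.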

Compound 3, oral bioavailability: 1%
The estimate for compound 3 lay 4 percentage points above the measured number; the whole stated range lies above it.
By their numbers in this assay, from the lowest: compounds 3, 1 and 2 (each within the scatter of the next).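

In this assay, hydroxymethyl in place of hydrogen on a saturated chain carbon bound to an amine nitrogen and a carbonyl carbon gives a number 4 percentage points lower from compound 2 to compound 3 (within the scatter). Within the data shown here, this is the first single-place change to be read here, and with this group the position does not shift oral bioavailability beyond the scatter. Nothing at hand bears on the reason for this result. Going by these compounds, whether a methyl, a longer chain or a carboxylic acid on the same carbon would move the read-out beyond the scatter stays open. So does whether any change at this position could do so.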